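Working notes: from compound 3 to compound 4

The source may hold more compounds than are shown below. What is called first, only, known or untested is meant among the compounds shown, and "the series" means these compounds.

- compound 1 `COc1ccc(/C=C/C(=O)c2ccc(OC)c3c2OC(C)(C)C=C3)cn1`: > 10000 nM (a limit)
- compound 2 `COc1ccc(C(=O)/C=C/c2ccco2)c2c1C=CC(C)(C)O2`: > 10000 nM (a limit)
- compound 3 `COc1ccc(C(=O)/C=C/c2ccccn2)c2c1C=CC(C)(C)O2`: 5400 nM

Going by the values given here, in a functional assay on K562 cells (Homo sapiens) for antiproliferative activity, read by MTT assay, with a stated time of 24 h (a lower number here means a stronger inhibitor, a higher number a weaker inhibitor), compound 3 gives 5400 nM, the only actual number so far. Compound 1 and compound 2 both sit at the limit of > 10000 nM in this assay, at which 2 of the 3 values shown sit.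

The next compound is compound 4 `COc1ccc(C(=O)/C=C/c2ccccc2Cl)c2c1C=CC(C)(C)O2`. The change is 2-chlorophenyl in place of pyridin-2-yl on a double-bonded chain carbon bound to a double-bonded chain carbon.

Among the compounds with values here, two measured steps bear on it, both made at this same place: an at least 1.8-fold lower number from compound 1 to compound 3 (0.26 log units; that floor lies within the scatter) and an at least 1.8-fold lower number from compound 2 to compound 3 (0.26 log units; that floor lies within the scatter). Both are floors rather than measured sizes, and neither involves 2-chlorophenyl, so they give no direct reading for this change and no firm direction.

No step beyond the scatter is expected in this assay. The estimated step is a 1.2-fold higher number from compound 3 to compound 4 (0.08 log units; within the scatter). A result reported only as a limit would also fit the series. For compound 4 the estimated value is 6500 nM, with an expected range of 2500 nM to 16000 nM.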

Compound 4, half-maximal inhibitory concentration: > 10000 nM
Compound 4: no number, only a limit; the forecaster's own chance of this, stated with the estimate: 35%; middle value at least 1.5-fold (0.18 log units) from the limit.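

In this assay compound 4 gives > 10000 nM, which is a limit and not a number. Placing 2-chlorophenyl in place of pyridin-2-yl on a double-bonded chain carbon bound to a double-bonded chain carbon gives an at least 1.8-fold higher number from compound 3 to compound 4 (0.26 log units; that floor lies within the scatter), so this carbon-only aromatic ring bearing chlorine brings no readable gain at this place, although the size of the step stays unknown and its floor lies within the scatter. Going by these compounds alone, compound 3 remains the only compound with an actual number, and the series now gathers at one ceiling: the limit of > 10000 nM in this assay, at which 3 of the 4 values shown sit.

The steps from compound 1 and from compound 2 to compound 4 join two limits and cannot be read, so these three compounds cannot be ordered. Going by these compounds, whether an amine or a carboxylic acid at this place would give a number below the ceiling stays open.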